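Amide-end variation on the shared core: cytotoxicity notes

This account rests on a few compounds, and the source may have more. Where it says the series, first, only, none or still open, it means among the compounds named here.

Measured so far:
compound 1 `COc1ccc2nc(C)cc(OCC(=O)Nc3cccc(C)c3)c2c1` — 39800 nM
compound 2 `COc1ccc2nc(C)cc(OCC(=O)Nc3cc(C)ccc3OC)c2c1` — a limit, > 100000 nM
compound 3 `COc1ccc2nc(C)cc(OCC(=O)Nc3cccnc3)c2c1` — a limit, > 100000 nM

In a toxicity assay on HepG2 cells (Homo sapiens) for inhibition, read by CellTiter-Glo, with a stated time of 48 h (on this read-out higher numbers stand for weaker inhibition and lower numbers for stronger inhibition), compound 1 gives 39800 nM. Compound 2 reaches only the limit of the assay, > 100000 nM. Compound 3 likewise reaches only the limit, > 100000 nM. Compound 3 thus stands at the limit of this assay, where (the limit of > 100000 nM in this assay, at which 2 of the 3 values shown sit); its number is a limit, not a measured value. The step of an at least 2.5-fold higher number from compound 1 to compound 3 (0.40 log units; beyond the scatter) is the only readable one leading to it, and the step that the two limits leave unreadable from compound 2 to compound 3 cannot be sized. Compound 4 `COc1ccc2nc(C)cc(OCC(=O)Nc3noc(C)c3C)c2c1` differs from compound 3 in 4,5-dimethyl-1,2-oxazol-3-yl in place of pyridin-3-yl on an amide-type nitrogen. Within the data shown here, the one readable step onto compound 3 ran up to the limit and the other is unreadable, so the numbers give no direction for the new amide end; the expectation is no step beyond the scatter, with the result most likely again a limit. Compound 4 is therefore expected at 100000 nM, within 40000 nM to 300000 nM, an estimated step of a number no higher from compound 3 to compound 4 (the limit leaves the size open).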

Compound 4, half-maximal inhibitory concentration: > 100000 nM
Compound 4: no number, only a limit (the forecaster's own chance of this, stated with the estimate: 65%); the middle value sits exactly at the limit.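

In this assay, 4,5-dimethyl-1,2-oxazol-3-yl in place of 3-methylphenyl on the amide-type nitrogen gives an at least 2.5-fold higher number from compound 1 to compound 4 (0.40 log units; beyond the scatter). Compound 1 remains the only one of the four with a number rather than a limit, and the amide ends at the limit now include a five-membered aromatic ring as well as six-membered ones: the limit of > 100000 nM in this assay, at which 3 of the 4 values shown sit. The steps among compound 2, compound 3 and compound 4 cannot be read, so they give no order among these amide ends.

Still open, on these data alone, is whether any other amide end gives a number under the limit, for example an aminoethyl chain or a benzoic acid. Also open, as far as these compounds go, is how much of the value of compound 1 rests on its methyl group, a question that a plain phenyl end would address.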